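Hydroxy on the core of compound 1

The source may hold more compounds than are shown below. What is called first, only, known or untested is meant among the compounds shown, and "the series" means these compounds.

In a functional assay on A549 cells (Homo sapiens) for inhibition, read by sulforhodamine B assay (a lower number here means a stronger inhibitor of growth, a higher number a weaker inhibitor of growth), compound 1 (`Fc1ccc(-c2ccc(-c3ccc(-c4nc5ccccc5[nH]4)cc3)cc2)cc1`) gives 33200 nM and compound 2 (`COc1ccc(-c2ccc(-c3ccc(-c4nc5ccccc5[nH]4)cc3)cc2)cc1`) gives 38100 nM; these two values lie within the scatter of each other, so neither ranks ahead. Compound 3 (`Oc1cccc2[nH]c(-c3ccc(-c4ccc(-c5ccc(F)cc5)cc4)cc3)nc12`) differs from compound 1 by hydroxy in place of hydrogen on an aromatic carbon. Within the data shown here, the only measured step, a 1.1-fold higher number from compound 1 to compound 2 (0.06 log units; within the scatter), is a different change, methoxy in place of fluoro, and no measured compound carries a hydroxy group, so it is weak guidance. Among the measured compounds shown here, on that basis, no step clearly beyond the scatter is expected in this assay, with a slight lean toward a lower number. Compound 3 is estimated at 24000 nM, with an expected range of 8000 nM to 55000 nM. The expected change is a 1.4-fold lower number from compound 1 to compound 3 (0.14 log units; within the scatter).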

Compound 3, concentration for 50% growth inhibition: 170 nM
Compound 3: the middle estimate sits 140-fold (2.15 log units) above what was measured; the whole stated range lies above it.
By their numbers in this assay, from the lowest: compound 3; then compounds 1 and 2 (each within the scatter of the next).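

In this assay, the core of compound 1 proves highly responsive at this aromatic carbon, ortho to a fused ring: hydroxy in place of hydrogen gives a 200-fold lower number from compound 1 to compound 3 (2.29 log units; beyond the scatter), whereas methoxy in place of fluoro gave only a 1.1-fold higher number from compound 1 to compound 2 (0.06 log units; within the scatter). A single added oxygen is therefore enough here to separate compound 3 from compounds 1 and 2. The data offer no evidence on what underlies this step.

Still open, on these data alone, is whether an amine or a carboxylic acid at the same carbon would give a comparable step. Also open, as far as these compounds go, is whether hydroxy has the same effect on the core of compound 2.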